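Amide aryl swap in a shared flavonol-type series

The source may hold more compounds than are shown below. What is called first, only, known or untested is meant among the compounds shown, and "the series" means these compounds.

Compound 1 `O=C(Nc1cccc(-c2oc3cc(-c4ccc(F)cc4)ccc3c(=O)c2O)c1)c1ccc(Br)cc1` — 24000 nM
Compound 2 `COc1ccc(C(=O)Nc2cccc(-c3oc4cc(-c5ccc(F)cc5)ccc4c(=O)c3O)c2)c(F)c1` — 20000 nM

Of the compounds shown here, two have been measured in a functional assay on MCF7 cells (Homo sapiens) for antiproliferative activity, read by CCK-8 assay, with a stated time of 72 h; a lower number here means a stronger inhibitor, a higher number a weaker inhibitor. Compound 1 gives 24000 nM, and compound 2 gives 20000 nM. Within the data shown here, the only measured step, a 1.2-fold lower number from compound 1 to compound 2 (0.08 log units; within the scatter), is an exchange of the aryl ring on the carbonyl carbon and stays within the scatter. Compound 2 therefore holds the lowest of the two numbers, though its gap to compound 1 is not beyond the scatter.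

Compound 3 `Cc1cc(C)cc(C(=O)Nc2cccc(-c3oc4cc(-c5ccc(F)cc5)ccc4c(=O)c3O)c2)c1` has not yet been measured. It differs from compound 2 by 3,5-dimethylphenyl in place of 2-fluoro-4-methoxyphenyl on a carbonyl carbon. Among the measured compounds shown here, the one step that bears on this, a 1.2-fold lower number from compound 1 to compound 2 (0.08 log units; within the scatter), changed the same aryl ring on the same carbonyl carbon and moved the number only within the scatter. The expectation for compound 3 in this assay is therefore no step beyond the scatter, a 1.1-fold higher number from compound 2 to compound 3 (0.04 log units; within the scatter). Compound 3 is estimated at 22000 nM, with a range from 10000 nM to 48000 nM.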

Compound 3, half-maximal inhibitory concentration: 20400 nM
The estimate for compound 3 lay 1.1-fold (0.03 log units) above the measured number, within the range that was stated.
By their numbers in this assay, from the lowest: compounds 2, 3 and 1 (each within the scatter of the next).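

At the carbonyl carbon whose other neighbour is the amide-type nitrogen, 3,5-dimethylphenyl, with no hydrogen-bond acceptor, replaces 2-fluoro-4-methoxyphenyl, which has one, and the read-out in this assay stays within the scatter (a 1.0-fold higher number from compound 2 to compound 3 (0.01 log units; within the scatter)). The exchange for 4-bromophenyl also stays within the scatter (a 1.2-fold lower number from compound 1 to compound 3 (0.07 log units; within the scatter)), so all three aryl groups at this position now lie within the scatter of one another, and no aryl group shown separates from the others. No independent measurement is available to explain this flat result.

From the compounds shown here alone, all three compounds carry a substituted phenyl ring here, so it remains open whether cyclohexyl, a ring bearing an amine, or one bearing a carboxylic acid would move the number. Going by these compounds, it is also open whether a change elsewhere on the shared core would take the number beyond the scatter.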